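Ester to anilide on the octanoyl linker

The compounds below may be only part of what the source reports. "The series", "measured", "known", "first", "only" and "open" are said of these compounds alone.

Within the data shown here, compound 2 `Cn1c(Cc2nn(C)c(=O)c3ccccc23)nnc1SCCCCCCCC(=O)Oc1ccc(Cl)cc1Cl` gives 800 nM in an assay on isolated protein (Mus musculus) for inhibition of IL15-IL15 receptor (Homo sapiens), read by resazurin assay, with stated times of 30 min and 2.5 days (on this read-out higher numbers stand for weaker inhibition and lower numbers for stronger inhibition), and stands at the lowest of the two numbers measured so far. Compound 1 `Cn1c(Cc2nn(C)c(=O)c3ccccc23)nnc1SCCCCCCCC(=O)Nc1ccc(O)cc1O` gives 17000 nM in this assay. Among the measured compounds shown here, the only measured step, a 21-fold lower number from compound 1 to compound 2 (1.33 log units; beyond the scatter), changed the oxygen-for-nitrogen link and the ring substituents together, so the two contributions cannot be separated on these data. Compound 3 `Cn1c(Cc2nn(C)c(=O)c3ccccc23)nnc1SCCCCCCCC(=O)Nc1ccc(F)cc1F` carries (2,4-difluorophenyl)amino in place of 2,4-dichlorophenoxy on a carbonyl carbon. This reverses the link back to an amide while keeping halogens on the ring, which is partly a return toward compound 1 and partly new ground. Because compound 2 gives 800 nM and compound 1 gives 17000 nM, a move back toward the higher number is expected for compound 3, but not the whole way. Compound 3 is estimated at 5000 nM, with a range from 1500 nM to 20000 nM. The expected step is a 6.3-fold higher number from compound 2 to compound 3 (0.80 log units; beyond the scatter).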

Compound 3, half-maximal inhibitory concentration: 2300 nM
Compound 3: the middle estimate sits 2.2-fold (0.34 log units) above what was measured, within the range that was stated.
By their numbers in this assay, from the lowest: compound 2; then compound 3; then compound 1.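

In this assay, holding the amide link and changing only the ring on the amide-type nitrogen gives a 7.4-fold lower number from compound 1 to compound 3 (0.87 log units; beyond the scatter), so the 2,4-dihydroxyphenyl to 2,4-difluorophenyl change matters by itself and the amide link does not fix the number at the level of compound 1. The other step, a 2.9-fold higher number from compound 2 to compound 3 (0.46 log units; beyond the scatter), still changes the link and the halogen together, so it does not assign the remaining difference to either one. No data shown here bear on the cause of either step.

From the compounds shown here alone, whether the ester link or the chlorine atoms favour compound 2 remains open. A 2,4-dichlorophenyl amide on the same octanoyl linker would separate the two, and an unsubstituted phenyl amide would give the reference for the halogens.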